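Adding a methoxy group to compound 2

This account rests on a few compounds, and the source may have more. Where it says the series, first, only, none or still open, it means among the compounds named here.

compound 1 `CC(C)Nc1ncnn2ccc(CN3CCC(N)CC3)c12` gives "not determined" (no result reported)
compound 2 `NC1CCN(Cc2ccn3ncnc(Nc4cccc(Cl)c4)c23)CC1` gives 60 nM

Within the data shown here, only one number exists so far in a functional assay on NCI-N87 cells (Homo sapiens) for antiproliferative activity (on this read-out lower numbers stand for stronger inhibition and higher numbers for weaker inhibition), and it belongs to compound 2, at 60 nM for half-maximal inhibition. Compound 1 has no reported result, so compound 2 cannot yet be ranked against anything.

The next compound is compound 3 `COc1ccc(Nc2ncnn3ccc(CN4CCC(N)CC4)c23)cc1Cl` with the rest of compound 2 unchanged apart from one edit. That edit, (methoxy in place of hydrogen on an aromatic carbon), turns 3-chlorophenyl into 3-chloro-4-methoxyphenyl, with the methoxy ortho to a chloro group and para to a large group.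

Among the measured compounds shown here, no measured pair shows what such a change does, so the expectation is loose: no shift beyond the usual scatter in this assay and no favoured direction. The expected 1.2-fold higher number from compound 2 to compound 3 (0.07 log units; within the scatter) is therefore small. For compound 3 the estimated value is 70 nM with an expected range from 20 nM to 250 nM in this test.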

Compound 3, half-maximal inhibitory concentration: 1210 nM
Beside the measured number, compound 3's estimate is 17-fold (1.24 log units) below it; the whole stated range lies below it.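

In this assay, adding the methoxy group gives a 20-fold higher number from compound 2 to compound 3 (1.30 log units; beyond the scatter) and so turns a small edit into a large loss of inhibition. Among these compounds, this is the first measured sign that the position on the 3-chlorophenyl ring, ortho to a chloro group and para to a large group, is sensitive to substitution, at least for methoxy. Nothing available explains why the number rises so sharply.

Still open, on these data alone, is whether this position penalises any added group or mainly methoxy, which a fluorine atom, a hydroxyl group or an amine in the same place could help to show. Also open, as far as these compounds go, is whether methoxy would cost as much on a phenyl ring without the chloro group, or whether a longer ethoxy chain would cost more.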